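Lengthening a Side Chain: From Compound 2 to Compound 3

The compounds below may be only part of what the source reports. "The series", "measured", "known", "first", "only" and "open" are said of these compounds alone.

Of the compounds shown here, two sharing one core have been measured in an ADME assay on BEAS-2B cells (Homo sapiens) for cytotoxicity, read by MTT assay, with a stated time of 72 h; a higher number here means a weaker inhibitor of growth, a lower number a stronger inhibitor of growth. Compound 1 `CCCOC(=O)Nc1ccc([Se]C#N)cc1` gives 46300 nM, and compound 2 `CC(C)COC(=O)Nc1ccc([Se]C#N)cc1` gives 49500 nM. Going by the values given here, the two numbers sit within the scatter of each other, so compound 2 stands alongside compound 1 rather than apart from it, as the single measured step shows: a 1.1-fold higher number from compound 1 to compound 2 (0.03 log units; within the scatter). Compound 3 `CCCCCCOC(=O)Nc1ccc([Se]C#N)cc1` has not yet been measured. It differs from compound 2 by pentyl in place of isopropyl on a saturated chain carbon bound to an oxygen next to a carbonyl group. Among the compounds with values here, the only step that bears on this change is the one from compound 1 to compound 2, which also altered the same chain and stayed within the scatter. On that basis the step from compound 2 to compound 3 is expected to be a 1.1-fold lower number from compound 2 to compound 3 (0.04 log units; within the scatter), no move beyond the scatter. Compound 3 is therefore estimated at 45000 nM in this assay, with a range from 20000 nM to 100000 nM.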

Compound 3, concentration for total growth inhibition: 35900 nM
Compound 3: the middle estimate sits 1.3-fold (0.10 log units) above what was measured; the range from low to high includes it.
By their numbers in this assay, from the lowest: compounds 3, 1 and 2 (each within the scatter of the next).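

Going from branched to straight and longer at this place, on a saturated chain carbon bound to an oxygen next to a carbonyl group, gives a 1.4-fold lower number from compound 2 to compound 3 (0.14 log units; within the scatter) in this assay, and lengthening the straight chain gives a 1.3-fold lower number from compound 1 to compound 3 (0.11 log units; within the scatter) as well. The earlier step added only a methyl, whereas these steps show that a larger change, to the hexyl chain of compound 3, also leaves the number within the scatter of both earlier compounds. No measured information is available to explain this result.

On these data alone, whether a much longer chain, or a chain ending in an amine or a carboxylic acid, would move the number beyond the scatter remains open. As far as these compounds go, how a change to the shared core, rather than to this chain, would compare also remains open.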